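The source may report more compounds than this note shows. Statements on the series, on what has been measured and on what is new or still open speak of the compounds shown alone.

Of the compounds shown here, two sharing one core have been tested in a functional assay on ileum for inhibition of histamine H1 receptor (Cavia porcellus); on this read-out higher numbers stand for weaker inhibition and lower numbers for stronger inhibition. Compound 1 `CN1CCCN(c2nc3ccccc3n2CCOc2ccccc2)CC1` gives 9.1 nM in this assay. Compound 2 `CCCCCCCCCCn1c(N2CCN(C)CC2)nc2ccccc21` gives 4200 nM in this assay, the higher of the two numbers, and its gap to compound 1 lies well beyond the scatter, so compound 2 is the weaker inhibitor of the pair. The two are not linked by a single change, so only their values can be set side by side.

Compound 3 `CCCn1c(N2CCN(C)CC2)nc2ccccc21` has not yet been measured. It differs from compound 2 in one place: hydrogen in place of heptyl on a saturated chain carbon, three bonds along the chain from an aromatic nitrogen. Among the compounds with values here, no measured pair shows what shortening this chain does, so the direction rests on weak ground. Because compound 2 gives 4200 nM, at the weak end of what is known, a modest move toward stronger inhibition is expected, a 2.8-fold lower number from compound 2 to compound 3 (0.45 log units; beyond the scatter), with a wide range. Compound 3 is estimated at 1500 nM, between 300 nM and 8000 nM.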

Compound 3, half-maximal inhibitory concentration: 380 nM
The estimate for compound 3 lay 3.9-fold (0.60 log units) above the measured number; measured number inside the range.
By their numbers in this assay, from the lowest: compound 1; then compound 3; then compound 2.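

Within the data shown here, putting hydrogen in place of heptyl on a saturated chain carbon, three bonds along the chain from an aromatic nitrogen, gives an 11-fold lower number from compound 2 to compound 3 (1.04 log units; beyond the scatter) in this assay and is the first change here that can be read on its own. The rest of the two structures stays the same, so this chain position clearly matters: removing these carbons alone moves the result well beyond the scatter, toward stronger inhibition. No measurement at hand explains why the shorter chain gives the lower number.

Chains of intermediate length, such as butyl or hexyl, would show whether the number changes gradually or abruptly with chain length. As far as these compounds go, it also remains open how a phenyl group or an amine at the end of this chain would compare.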